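Replacing the phenyl of compound 2 with hydroxymethyl

The source may report more compounds than this note shows. Statements on the series, on what has been measured and on what is new or still open speak of the compounds shown alone.

Two analogues on the shared core have been measured. Compound 1 `COC(=O)c1ccc(NC2=CC(=O)c3ncncc3C2=O)cc1` gives 1100 nM in a functional assay on PANC-1 cells (Homo sapiens) for cytotoxicity, read by MTT assay, with a stated time of 72 h; on this read-out higher numbers stand for weaker inhibition and lower numbers for stronger inhibition. Compound 2 `O=C1C(Nc2ccc(-c3ccccc3)cc2)=CC(=O)c2ncncc21` gives 400 nM in this assay. The step between them is a 2.8-fold lower number from compound 1 to compound 2 (0.44 log units; beyond the scatter). Compound 2 thus holds the lowest of the two numbers, with compound 1 the nearest and higher by a margin beyond the scatter.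

Compound 3 `O=C1C(Nc2ccc(CO)cc2)=CC(=O)c2ncncc21` differs from compound 2 by hydroxymethyl in place of phenyl on an aromatic carbon. Going by the values given here, no measured step covers this exact exchange; the single known step, a 2.8-fold lower number from compound 1 to compound 2 (0.44 log units; beyond the scatter), shows only that a group other than phenyl at this position went with a higher number beyond the scatter. The expectation for compound 3 in this assay is therefore a higher number, a step of a 2.5-fold higher number from compound 2 to compound 3 (0.40 log units; beyond the scatter), placing it near compound 1. Compound 3 is estimated at 1000 nM, with a range from 400 nM to 2500 nM.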

Compound 3, half-maximal inhibitory concentration: 1000 nM
For compound 3 middle estimate and measured number coincide at the digits printed; measured number inside the range.
By their numbers in this assay, from the lowest: compound 2; then compounds 3 and 1 (each within the scatter of the next).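

In this assay, hydroxymethyl on the aromatic carbon para to a large group gives a 2.5-fold higher number from compound 2 to compound 3 (0.40 log units; beyond the scatter) and so joins methoxycarbonyl as a second replacement that loses ground against phenyl. The comparison of those two replacements gives a 1.1-fold lower number from compound 1 to compound 3 (0.04 log units; within the scatter), so among the three groups shown, the lowest number stays with phenyl, the only one with a ring, while the two without a ring cannot be told apart. No measurement here accounts for the difference between phenyl and the other two groups.

From the compounds shown here alone, whether the aromatic ring itself matters or only the size of the group remains open, and cyclohexyl or a longer alkyl chain at this place would address that. An amine or a carboxylic acid on the same carbon also remains untested in the compounds shown.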